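Notes on the sulfur-linked group of the series

The source may hold more compounds than are shown below. What is called first, only, known or untested is meant among the compounds shown, and "the series" means these compounds.

Measured in a toxicity assay on GES1 cells (Homo sapiens) for inhibition, read by MTT assay, with a stated time of 72 h; on this read-out higher numbers stand for weaker inhibition and lower numbers for stronger inhibition:
- compound 1 `Cc1cc(N2CC[C@@H](C)[C@@H](N(C)c3ncnc4[nH]ccc34)C2)n2nc(SCc3ccc(Cl)cc3)nc2n1`: > 100000 nM (a limit of the assay)
- compound 2 `Cc1cc(N2CC[C@@H](C)[C@@H](N(C)c3ncnc4[nH]ccc34)C2)n2nc(SCc3nc4ccccc4[nH]3)nc2n1`: 40200 nM

For the measured compounds named here, compound 2, at 40200 nM, holds the only actual number so far. Compound 3 `Cc1cc(N2CC[C@@H](C)[C@@H](N(C)c3ncnc4[nH]ccc34)C2)n2nc(SCc3ccccc3Br)nc2n1` has 2-bromophenyl in place of 1H-benzimidazol-2-yl on a saturated chain carbon bound to a sulfur. Going by the values given here, the one measured step bearing on this is an at least 2.4-fold lower number from compound 1 to compound 2 (0.39 log units; beyond the scatter), which brought in the 1H-benzimidazol-2-yl that compound 3 gives up. A modest move to a higher number in this assay is therefore expected, an estimated 2.1-fold higher number from compound 2 to compound 3 (0.33 log units; beyond the scatter). For compound 3 the expected value is 85000 nM, with an estimated range of 35000 nM to 200000 nM.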

Compound 3, half-maximal inhibitory concentration: > 100000 nM
Compound 3: only a limit was reported (the forecaster's own chance of this, stated with the estimate: 45%); middle value at least 1.1-fold (0.07 log units) away from the limit.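

On the saturated chain carbon bound to a sulfur, the change to 2-bromophenyl reads in this assay as an at least 2.4-fold higher number from compound 2 to compound 3 (0.39 log units; beyond the scatter), so a second halogen-bearing phenyl group, not only 4-chlorophenyl, comes without an actual number. Of the three compounds only compound 2 gives one, and the two phenyl groups cannot be ordered, since the step between them cannot be read: the limit of > 100000 nM in this assay, at which 2 of the 3 values shown sit.

Still open, going by these compounds, is whether a 1H-imidazol-2-yl or pyridin-2-yl group on the same carbon would also give an actual number, or whether this needs the whole 1H-benzimidazol-2-yl group.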